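A few compounds are considered here, and "the series" means these few. Any claim that something is new, unique, unknown or untested is made for them only; others in the source may bear on it.

Measured in a functional assay on MCF7 cells (Homo sapiens) for inhibition, read by MTT assay; a higher number here means a weaker inhibitor, a lower number a stronger inhibitor:
compound 1 `COc1cc2ncnc(Nc3ccc(NC(=O)c4ccccc4Cl)cc3)c2cc1OC`: 36000 nM
compound 2 `COc1cc2ncnc(Nc3ccc(NC(=O)c4ccccc4I)cc3)c2cc1OC`: 37000 nM

Compound 2 stands level with compound 1 on these two numbers. Compound 3 `COc1cc2ncnc(Nc3ccc(NC(=O)c4cccc(I)c4)cc3)c2cc1OC` is still unmeasured and differs from compound 2 as follows: 3-iodophenyl in place of 2-iodophenyl on a carbonyl carbon. Going by the values given here, the only measured step is a 1.0-fold higher number from compound 1 to compound 2 (0.01 log units; within the scatter). That step exchanges chloro for iodo and does not move the iodine, and it bears on the new change only indirectly. Among the compounds with values here, no measured step tests the move from 2-iodophenyl to 3-iodophenyl. In this assay, no change beyond the scatter is expected, with the expected step being a 1.2-fold lower number from compound 2 to compound 3 (0.09 log units; within the scatter). Compound 3 is estimated at 30000 nM, with an expected range of 12000 nM to 70000 nM.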

Compound 3, half-maximal inhibitory concentration: 30000 nM
Estimate against measurement, compound 3: no gap at the digits printed, within the range that was stated.
By their numbers in this assay, from the lowest: compounds 3, 1 and 2 (each within the scatter of the next).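

In this assay the move from 2-iodophenyl to 3-iodophenyl on the carbonyl carbon gives a 1.2-fold lower number from compound 2 to compound 3 (0.09 log units; within the scatter) as the first measured test of where the iodine sits. Changing halogen and place together, 3-iodophenyl in place of 2-chlorophenyl, gives a 1.2-fold lower number from compound 1 to compound 3 (0.08 log units; within the scatter) and also leaves the number within the scatter. Nothing at hand bears on why these numbers stay level.

From the compounds shown here alone, whether an amine or a carboxylic acid in place of the iodine would move the number beyond the scatter in this assay stays open.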